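Chain homologues of an ester series: cytotoxicity notes

The compounds below may be only part of what the source reports. "The series", "measured", "known", "first", "only" and "open" are said of these compounds alone.

Measured so far:
compound 1, `CCCCCCOC(=O)CCC(=O)N1CCN(CCCOc2cc3c(Nc4ccc(F)c(Cl)c4)ncnc3cc2OC)CC1`, 89.3%
compound 2, `CCCCCCCOC(=O)CCC(=O)N1CCN(CCCOc2cc3c(Nc4ccc(F)c(Cl)c4)ncnc3cc2OC)CC1`, 89.1%
compound 3, `CCCCCCCCCOC(=O)CCC(=O)N1CCN(CCCOc2cc3c(Nc4ccc(F)c(Cl)c4)ncnc3cc2OC)CC1`, 90%

In a functional assay on A549 cells (Homo sapiens) for cytotoxicity, read by MTT assay, with a stated time of 24 h, tested at 10 uM (a lower number here means a stronger effect, a higher number a weaker effect of the compound at the concentration tested), compound 1 gives 89.3%, compound 2 gives 89.1% and compound 3 gives 90%. The change from compound 1 to compound 2 is methyl in place of hydrogen on a saturated chain carbon, six bonds along the chain from an oxygen next to a carbonyl group; the step it made was a number 0.2 percentage points lower from compound 1 to compound 2 (within the scatter). Compound 3 differs from compound 1 by propyl in place of hydrogen on a saturated chain carbon, six bonds along the chain from an oxygen next to a carbonyl group. Compound 4, `CCCCCCCCCCOC(=O)CCC(=O)N1CCN(CCCOc2cc3c(Nc4ccc(F)c(Cl)c4)ncnc3cc2OC)CC1`, is not yet measured; it differs from compound 3 by methyl in place of hydrogen on a saturated chain carbon, nine bonds along the chain from an oxygen next to a carbonyl group, the same kind of change as from compound 1 to compound 2, but placed nine bonds along the chain rather than six. All three measured values lie within the usual scatter of one another, so lengthening the chain has so far shown no effect. The step to compound 4 is expected to be no change at the digits printed from compound 3 to compound 4 (within the scatter), resting on the earlier step being a number 0.2 percentage points lower from compound 1 to compound 2 (within the scatter). Compound 4 is therefore estimated at 90%, between 84% and 96%.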

Compound 4, a percentage reported as activity, at one concentration (the size of the read-out at that concentration, not a potency): 95.7%
For compound 4 the middle estimate is 5.7 percentage points below the measured one, and the stated range covers the measured number.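

In this assay the chain steps read a number 5.7 percentage points higher from compound 3 to compound 4 (within the scatter), a number 6.6 percentage points higher from compound 2 to compound 4 (within the scatter) and a number 6.4 percentage points higher from compound 1 to compound 4 (within the scatter), so none stands clear of the usual scatter. The methyl change shows no detectable dependence on the core it is placed on: the same change on two cores in this assay, a number 0.2 percentage points lower (within the scatter) from compound 1 to compound 2 and a number 5.7 percentage points higher (within the scatter) from compound 3 to compound 4, 5.9 percentage points apart, within the scatter of two such steps. Going by these compounds alone, the propyl change reads alike, but with every step inside the scatter this shows only that no difference between cores can be seen, not that either change carries a real effect from one core to another: the same change on two cores in this assay, a number 0.7 percentage points higher (within the scatter) from compound 1 to compound 3 and a number 6.6 percentage points higher (within the scatter) from compound 2 to compound 4, 5.9 percentage points apart, within the scatter of two such steps.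

The compounds shown are all straight-chain esters on the shared core, so a branched chain, a longer chain or a chain ending in an amine or a carboxylic acid remains open. Readings at a single concentration also leave potency open.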